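The source may report more compounds than this note shows. Statements on the series, on what has been measured and on what is new or still open speak of the compounds shown alone.

Measured so far:
compound 1 `COC(=O)/C=C/c1cccc(N(Cc2ccc(-c3ccc(F)c(F)c3)cc2)C(=O)C2CCCCC2)c1`: 72 nM
compound 2 `COC(=O)/C=C/c1cccc(N(Cc2ccc(-c3cc(Cl)ccc3OC)cc2)C(=O)C(C)C)c1`: 226 nM
compound 3 `COC(=O)/C=C/c1cccc(N(Cc2ccc(/C=C/C(=O)OC(C)(C)C)cc2)C(=O)c2ccccc2)c1`: 236 nM

All three were run in an assay on isolated protein with Bile acid receptor (Homo sapiens) as the target; a lower number here means that less compound is needed, a higher number that more compound is needed for the effect. Compound 1 gives the lowest number of the three, and the gaps to compound 2 and to compound 3 both lie beyond the scatter, so compound 1 stands as the most potent of this set.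

Compound 4 `COC(=O)/C=C/c1cccc(N(Cc2ccc(/C=C/C(=O)OCc3ccccc3)cc2)C(=O)C2CCCCC2)c1` has not been measured. It keeps the core of compound 1 and differs in one place: 2-(benzyloxycarbonyl)ethenyl in place of 3,4-difluorophenyl on an aromatic carbon.

Going by the values given here, no measured pair shows this change directly. Compound 3, which also carries an ester-bearing ethenyl group in that position, sits clearly above compound 1, although its amide part differs too. On that basis compound 4 is expected to come out somewhat weaker than compound 1, with an estimated step of a 2.1-fold higher number from compound 1 to compound 4 (0.32 log units; beyond the scatter). The estimate for compound 4 is 150 nM, within 50 nM to 450 nM.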

Compound 4, half-maximal effective concentration: > 1000 nM
Compound 4 gave a limit, no number; the forecaster's own chance of this, stated with the estimate: 5%; middle value at least 6.6-fold (0.82 log units) away from the limit.
By their numbers in this assay, from the lowest: compound 1; then compounds 2 and 3 (each within the scatter of the next). At a limit, above all of these: compound 4.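

In this assay compound 4 gives > 1000 nM, which is a limit of the assay and not a number. With the rest of the core of compound 1 unchanged, 2-(benzyloxycarbonyl)ethenyl in place of 3,4-difluorophenyl gives an at least 13-fold higher number from compound 1 to compound 4 (1.14 log units; beyond the scatter). This first one-place change in the series shows that the number in this assay is sensitive to the group on this aromatic carbon, para to a large group.

A single change cannot separate the part played by the ethenyl linker from that of the benzyl ester. As far as these compounds go, how a carboxylic acid or an amine at this position would read in this assay remains open.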